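The source may report more compounds than this note shows. Statements on the series, on what has been measured and on what is new or still open speak of the compounds shown alone.

Compound 1, with the structure `CC(C)[C@H](C[C@H]1OC(=O)NC1=O)c1ccc(-c2ccc3cccc(F)c3c2)[nH]c1=O`, is the strongest of the three compounds measured here. In a functional assay on CHO cells for antagonist activity at prostaglandin E2 receptor EP3 subtype (Homo sapiens), read by cAMP accumulation, with a stated time of 30 min (a higher number here means a weaker inhibitor, a lower number a stronger inhibitor), compound 1 gives 15 nM. Compound 2, with the structure `CCC(/C=C1\OC(=O)NC1=O)(CC)c1ccc(-c2ccc3cccc(F)c3c2)[nH]c1=O`, gives 61 nM in this assay, a weaker result lying beyond the scatter. Compound 3, with the structure `CC(C)C(/C=C1\NC(=O)NC1=O)c1ccc(-c2ccc3cccc(F)c3c2)[nH]c1=O`, gives 87 nM in this assay, the weakest of the three and again beyond the scatter from compound 1. No two of these compounds differ in only one place, so no single step between measured compounds can be read off.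

Compound 4, with the structure `CC(C)[C@H](C[C@@H]1OC(=O)NC1=O)c1ccc(-c2ccc3cccc(F)c3c2)[nH]c1=O`, has not yet been measured in this assay. Its difference from compound 1 is: the two compounds have the same atoms and bonds and differ only in configuration as drawn: 1 of 2 stereo elements differ; a stereocentre at a saturated ring carbon is drawn R in compound 1 and S in compound 4. The change keeps every atom and bond and alters only the handedness at one ring carbon of the five-membered ring bearing the two carbonyls. Within the data shown here, nothing among the measured compounds shows how such a flip of configuration plays out, so the expectation rests on the general experience that mirror-image arrangements at a single centre can shift potency either way. Given that compound 1 gives 15 nM, the step from compound 1 to compound 4 is expected to be a 4.0-fold higher number from compound 1 to compound 4 (0.60 log units; beyond the scatter), a loss of potency. Compound 4 is therefore estimated at 60 nM, with a range from 15 nM to 250 nM.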

Compound 4, half-maximal inhibitory concentration: 27 nM
Estimate against measurement, compound 4: 2.2-fold (0.35 log units) above; measured number inside the range.
By their numbers in this assay, from the lowest: compounds 1 and 4 (each within the scatter of the next); then compounds 2 and 3 (each within the scatter of the next).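

Among these compounds, compound 1 and compound 4 form the first pair here that can be read as a single change, and the comparison is a clean one, as the only thing separating them is this: the fact that compounds 1 and 4 differ only in the configuration as drawn. In this assay, turning the ring carbon from R to S gives a 1.8-fold higher number from compound 1 to compound 4 (0.26 log units; within the scatter), so at this position the two drawn configurations cannot be told apart by this measurement. Neither arrangement at this carbon is therefore shown to be required for a result in this range, which is something the earlier compounds could not show, since no two of them differed in only one place.

The compounds shown leave open whether the other stereo element, drawn the same in compound 1 and compound 4, would prove just as indifferent if it were inverted. They also leave open what the five-membered ring bearing the two carbonyls itself contributes, for instance whether a carboxylic acid in its place would give a value close to those of compound 1 and compound 4 in this assay.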